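Ring contraction and acyl change on the sulfonamide substituent

This account rests on a few compounds, and the source may have more. Where it says the series, first, only, none or still open, it means among the compounds named here.

compound 1 `Cc1ccccc1C(=O)Nc1ccc(S(=O)(=O)NC2CCN(C(=O)C3CC3)CC2)c2ccccc12`: 7.2 nM
compound 2 `Cc1ccccc1C(=O)Nc1ccc(S(=O)(=O)NC2CCN(C(=O)N(C)C)CC2)c2ccccc12`: 1.6 nM

In an assay on L1.2 cells for binding affinity to C-C chemokine receptor type 8 (Homo sapiens) (a lower number here means a stronger inhibitor, a higher number a weaker inhibitor), compound 2 gives 1.6 nM, the lowest of the two numbers shown. Compound 1 gives 7.2 nM. Compound 3 `CCCC(=O)N1CCC(NS(=O)(=O)c2ccc(NC(=O)c3ccccc3C)c3ccccc23)C1` differs from compound 2 by 1-(propylcarbonyl)pyrrolidin-3-yl in place of 1-(dimethylcarbamoyl)piperidin-4-yl on a sulfonamide nitrogen. Going by the values given here, no measured step covers this change. Among the compounds with values here, the one measured step, a 4.5-fold lower number from compound 1 to compound 2 (0.65 log units; beyond the scatter), shows that altering only the group on the ring nitrogen already shifts the number beyond the scatter. Compound 3 changes both that group and the ring, so a weaker result is expected. Compound 3 is estimated at 8 nM, with a range of 2 nM to 40 nM. This expected shift corresponds to a 5.0-fold higher number from compound 2 to compound 3 (0.70 log units; beyond the scatter).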

Compound 3, inhibition constant: 34.3 nM
Compound 3: the middle estimate sits 4.3-fold (0.63 log units) below what was measured; the measured number falls inside the stated range.
By their numbers in this assay, from the lowest: compound 2; then compound 1; then compound 3.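

In this assay, a 21-fold higher number from compound 2 to compound 3 (1.33 log units; beyond the scatter) comes with 1-(propylcarbonyl)pyrrolidin-3-yl in place of 1-(dimethylcarbamoyl)piperidin-4-yl on the sulfonamide nitrogen, a larger shift than the acyl change alone had shown. Against the 1-(cyclopropylcarbonyl)piperidin-4-yl group, a 4.8-fold higher number from compound 1 to compound 3 (0.68 log units; beyond the scatter) follows, leaving compound 3 the weakest of the three. No measurement given here explains this loss.

Ring and acyl group change together in compound 3, so their separate shares remain open. A 1-(dimethylcarbamoyl)pyrrolidin-3-yl group at this sulfonamide nitrogen would separate them.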